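Moving the amino group: a second look at the same swap

The compounds below may be only part of what the source reports. "The series", "measured", "known", "first", "only" and "open" are said of these compounds alone.

Measured so far:
compound 1, `COc1cc(C(=O)c2cn(-c3ccc(C)cc3)cc2-c2cccc(N)c2)cc(OC)c1OC`: 53 nM
compound 2, `COc1cc(C(=O)c2cn(-c3ccc(C)cc3)cc2-c2ccc(N)cc2)cc(OC)c1OC`: 6 nM
compound 3, `COc1cc(C(=O)c2cn(-c3ccc(N)cc3)cc2-c2cccc(N)c2)cc(OC)c1OC`: 78 nM

The three measured compounds were tested in a functional assay on MCF7 cells (Homo sapiens) for cytotoxicity, read by MTT assay, with a stated time of 96 h; a lower number here means a stronger inhibitor, a higher number a weaker inhibitor. Compound 1 and compound 2 differ in one place: 4-aminophenyl in place of 3-aminophenyl on an aromatic carbon. That change made a sizeable step, an 8.8-fold lower number from compound 1 to compound 2 (0.95 log units; beyond the scatter). Compound 3 differs from compound 1 in a different place: amino in place of methyl on an aromatic carbon. This second change hardly moved the reading, since a 1.5-fold higher number from compound 1 to compound 3 (0.17 log units; within the scatter).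

Compound 4, `COc1cc(C(=O)c2cn(-c3ccc(N)cc3)cc2-c2ccc(N)cc2)cc(OC)c1OC`, has not been measured. It relates to compound 3 as compound 2 relates to compound 1: 4-aminophenyl in place of 3-aminophenyl on an aromatic carbon. The two cores are not identical. The core of compound 3 carries the change described by amino in place of methyl on an aromatic carbon, and the surroundings of the swapped group differ accordingly, one core bearing a 4-methylphenyl group and the other a 4-aminophenyl group two ring bonds away. So this is the same kind of change, made on a slightly different core, not the same change.

The core difference by itself stayed within the scatter, as a 1.5-fold higher number from compound 1 to compound 3 (0.17 log units; within the scatter) shows, and the earlier step read an 8.8-fold lower number from compound 1 to compound 2 (0.95 log units; beyond the scatter). On that basis the step from compound 3 to compound 4 is expected to be similar, roughly an 8.7-fold lower number from compound 3 to compound 4 (0.94 log units; beyond the scatter). Accordingly compound 4 is estimated to give 9 nM in this assay, expected to fall between 4 nM and 22 nM.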

Compound 4, half-maximal inhibitory concentration: 15 nM
For compound 4 the middle estimate is 1.7-fold (0.22 log units) below the measured one; the range from low to high includes it.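

In this assay the move from 3-aminophenyl to 4-aminophenyl again lowers the number on the second core, with a 5.2-fold lower number from compound 3 to compound 4 (0.72 log units; beyond the scatter), and the gap to the first core's step is small: the same change on two cores in this assay, an 8.8-fold lower number (0.95 log units; beyond the scatter) from compound 1 to compound 2 and a 5.2-fold lower number (0.72 log units; beyond the scatter) from compound 3 to compound 4, 1.7-fold (0.23 log units) apart, within the scatter of two such steps. The other change, amino in place of methyl, gives a 2.5-fold higher number from compound 2 to compound 4 (0.40 log units; beyond the scatter), and although this step lies beyond the scatter while its earlier counterpart did not, the two steps do not differ by more than the scatter: the same change on two cores in this assay, a 1.5-fold higher number (0.17 log units; within the scatter) from compound 1 to compound 3 and a 2.5-fold higher number (0.40 log units; beyond the scatter) from compound 2 to compound 4, 1.7-fold (0.23 log units) apart, within the scatter of two such steps. So across these four compounds each change keeps a similar size when carried from one core to the other, but this rests on a single pair of cores in one cell assay and does not show that the same steps would hold on other cores or explain why the position of the amino group matters.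

The compounds shown leave open how the step would read if a hydroxyl group or a dimethylamino group took the place of the amino group on the 4-aminophenyl ring. They also leave open whether the move would carry over with a chlorine atom or an ethyl group in place of the methyl of the 4-methylphenyl group.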